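The compounds below may be only part of what the source reports. "The series", "measured", "known", "first", "only" and "open" are said of these compounds alone.

Working notes on the series, read out in a functional assay on A-375 cells (Homo sapiens) for antiproliferative activity; a lower number here means a stronger inhibitor, a higher number a weaker inhibitor. Compound 1 `O=C(Nc1ccc(-c2ccccc2)cc1)C1CCCN(Cc2ccc(F)c(F)c2)C1` gives 2580 nM, compound 2 `O=C(Nc1ccc(-c2ccn[nH]2)cc1)C1CCCN(Cc2ccc(F)c(F)c2)C1` gives 520 nM, and compound 3 `O=C(Nc1ccc(-c2cc[nH]c2)cc1)C1CCCN(Cc2ccc(F)c(F)c2)C1` gives 1420 nM. Compound 3 cannot be told apart from compound 1, the step being a 1.8-fold lower number from compound 1 to compound 3 (0.26 log units; within the scatter). It stands clear of compound 2, with a 2.7-fold higher number from compound 2 to compound 3 (0.44 log units; beyond the scatter), and compound 2 is the most potent of the three, with a 5.0-fold lower number from compound 1 to compound 2 (0.70 log units; beyond the scatter).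

Compound 4 `O=C(Nc1ccc(-c2ccc[nH]2)cc1)C1CCCN(Cc2ccc(F)c(F)c2)C1` is the next comparison: 1H-pyrrol-2-yl in place of 1H-pyrrol-3-yl on an aromatic carbon. It carries 1H-pyrrol-2-yl in place of 1H-pyrrol-3-yl on an aromatic carbon, para to a large group, and the rest of the structure is unchanged. Among the measured compounds shown here, no measured step makes this exact exchange. For the measured compounds named here, the three steps above are the only guide, and they show that exchanges at this place have moved the number by modest amounts at most. They give no firm direction for a shift of the pyrrole attachment, so only a slight lean towards compound 2 at 520 nM is allowed. The expected change in this assay is a 1.5-fold lower number from compound 3 to compound 4 (0.17 log units; within the scatter), with no firm expectation of a step beyond the scatter. Compound 4 is estimated at 950 nM, with an expected range of 400 nM to 2300 nM.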

Compound 4, half-maximal inhibitory concentration: 360 nM
For compound 4 the middle estimate is 2.6-fold (0.42 log units) above the measured one; measured number outside the range, below it.
By their numbers in this assay, from the lowest: compounds 4 and 2 (each within the scatter of the next); then compounds 3 and 1 (each within the scatter of the next).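

In this assay, moving the attachment of the same pyrrole ring from 1H-pyrrol-3-yl to 1H-pyrrol-2-yl on this aromatic carbon, para to a large group, changes the number on its own (a 3.9-fold lower number from compound 3 to compound 4 (0.60 log units; beyond the scatter)), so at this place the point of attachment counts and not merely the presence of a five-membered aromatic ring with a nitrogen in it. The 1H-pyrrol-2-yl group cannot be told apart from 1H-pyrazol-5-yl (a 1.4-fold lower number from compound 2 to compound 4 (0.16 log units; within the scatter)), yet it stands clear of phenyl (a 7.2-fold lower number from compound 1 to compound 4 (0.86 log units; beyond the scatter)), which gives two five-membered rings at a similar level and leaves 1H-pyrrol-3-yl, within the scatter of phenyl, as the one that goes against any general benefit of such a ring. Nothing measured on these compounds accounts for the effect of the attachment point.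

The compounds shown leave open whether the hydrogen on the pyrrole nitrogen is needed, which a methyl on that nitrogen or a furan-2-yl group in its place would test. They also leave open how an imidazol-2-yl group or a carboxylic acid would read at this same carbon.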